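The source may report more compounds than this note shows. Statements on the series, on what has been measured and on what is new or still open speak of the compounds shown alone.

Of the compounds shown here, three have been tested in a functional assay on cells (Mus musculus) for cytotoxicity, read by MTT assay, with a stated time of 24 h, tested at 10 uM; a lower number here means a weaker effect, a higher number a stronger effect of the compound at the concentration tested. Compound 1 `COc1cc(/C=N/N(C)c2nc3ccccc3s2)cc(OC)c1O` gives 110%. Compound 3 `COc1cc(/C=N/N(C)c2nc3ccccc3s2)ccc1O` differs from compound 1 in one place, namely (hydrogen in place of methoxy on an aromatic carbon), and in this assay compound 3 gives 96%; the step from one to the other is a number 14 percentage points lower from compound 1 to compound 3 (beyond the scatter). Compound 2 `COc1cc(/C=N/N2C(=O)CSC2=S)cc(OC)c1O` rests on a different core; the difference between the two cores is not broken down here. In this assay compound 2 gives 85%, the lowest of the three numbers. Compound 4 `COc1cc(/C=N/N2C(=O)CSC2=S)ccc1O` has not yet been measured. It differs from compound 2 by hydrogen in place of methoxy on an aromatic carbon, the same kind of change as from compound 1 to compound 3, here meta to a group of 9 heavy atoms where the earlier change was meta to a large group. Because the earlier change gave a number 14 percentage points lower from compound 1 to compound 3 (beyond the scatter), a step of about the same size is expected here, a number 13 percentage points lower from compound 2 to compound 4 (beyond the scatter). Compound 4 is therefore estimated at 72%, probably between 58% and 86%.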

Compound 4, a percentage reported as activity, at one concentration (the size of the read-out at that concentration, not a potency): 72%
Estimate against measurement, compound 4: no gap at the digits printed; the range from low to high includes it.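

In this assay putting hydrogen in place of methoxy gives a number 13 percentage points lower from compound 2 to compound 4 (beyond the scatter) and this step can be set beside the earlier one on the other core: the same change on two cores in this assay, a number 14 percentage points lower (beyond the scatter) from compound 1 to compound 3 and a number 13 percentage points lower (beyond the scatter) from compound 2 to compound 4, 1 percentage points apart, within the scatter of two such steps. In these two pairs, then, the change carried over from one core to the other at about the same size. This rests on two pairs at a single concentration, so it does not show that the step would hold on other cores, nor why the number is lower. The compounds shown leave open what other groups on that aromatic carbon would do, such as an amine, a carboxylic acid or a longer chain like ethoxy.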